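Shortening the Alkoxy Chain of a Bis-Sulfonamide

The source may hold more compounds than are shown below. What is called first, only, known or untested is meant among the compounds shown, and "the series" means these compounds.

In an ADME assay on L929 cells (Mus musculus) for cytotoxicity, read by CCK-8 assay, with a stated time of 48 h, tested at 10 uM (a higher number here means a weaker effect of the compound at the concentration tested, a lower number a stronger effect), compound 2 `CCOc1ccc(S(=O)(=O)N2CCN(Cc3ccccc3)CC2)cc1S(=O)(=O)N1CCN(Cc2ccccc2)CC1` gives 55.6%, the lowest of the three numbers measured. Compound 1 `COc1ccc(S(=O)(=O)N2CCN(c3ccccc3F)CC2)cc1S(=O)(=O)N1CCN(c2ccccc2F)CC1` gives 77.8% and compound 3 `COc1ccc(S(=O)(=O)N2CCN(c3cccc(C)c3)CC2)cc1S(=O)(=O)N1CCN(c2cccc(C)c2)CC1` gives 85.2%, both lying beyond the scatter above compound 2. Compound 4 `COc1ccc(S(=O)(=O)N2CCN(Cc3ccccc3)CC2)cc1S(=O)(=O)N1CCN(Cc2ccccc2)CC1` has not yet been measured; its change from compound 2 is hydrogen in place of methyl on a saturated chain carbon bound to an oxygen on an aromatic ring. Within the data shown here, no step between two measured compounds isolates this change, and compounds 1 and 3 each differ from compound 2 in more than one place, so the record gives no direct guide. The author expects a small step in this assay, estimated as a number 6.4 percentage points higher from compound 2 to compound 4 (within the scatter), which he does not expect to reach clearly beyond the scatter. Compound 4 is therefore expected to give about 62%, within a range from 45% to 82%.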

Compound 4, a percentage reported as activity, at one concentration (the size of the read-out at that concentration, not a potency): 55.6%
Compound 4: middle estimate off by 6.4 percentage points, on the high side, within the range that was stated.
By their numbers in this assay, from the lowest: compounds 2 and 4 (each within the scatter of the next); then compounds 1 and 3 (each within the scatter of the next).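

In this assay, among these compounds, ethoxy to methoxy gives no change at the digits printed from compound 2 to compound 4 (within the scatter), the first step that isolates this change on a saturated chain carbon bound to an oxygen on an aromatic ring. On the core shared by these two compounds, the methyl can therefore leave this place with no change that the read-out can resolve. Nothing available bears on why this is so.

From the compounds shown here alone, whether a longer chain such as propoxy, or an amine, would be tolerated at this place remains open. So does whether ethoxy to methoxy would read the same in the setting of compound 1 or compound 3.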